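Hydroxy to Carboxy: Estimating the Read-out of Compound 4

The source may report more compounds than this note shows. Statements on the series, on what has been measured and on what is new or still open speak of the compounds shown alone.

Compound 2 `COc1ccc2nc(C(=O)Nc3ccc(-c4ccccc4)cc3)c(C)c(O)c2c1` stands highest of the three compounds measured in a functional assay on A-375 cells (Homo sapiens) for antiproliferative activity, read by MTT assay, with a stated time of 24 h, tested at 1.23 ug/mL (on this read-out higher numbers stand for a stronger effect at the one concentration tested and lower numbers for a weaker effect), where compound 2 gives 18.7%. Compound 3 `Cc1c(C(=O)Nc2ccc(-c3ccccc3)cc2)nc2ccccc2c1O` gives 4.56%, and compound 1 `Cc1c(C(=O)Nc2c(F)cc(-c3cccc(F)c3)cc2F)nc2ccc(F)cc2c1O` gives 2.34%. Going by the values given here, the only measured step, a number 14.1 percentage points lower from compound 2 to compound 3 (beyond the scatter), concerns a different change and does not bear on the one considered here. Compound 4 `COc1ccc2nc(C(=O)Nc3ccc(-c4ccccc4)cc3)c(C)c(C(=O)O)c2c1` differs from compound 2 by carboxy in place of hydroxy on an aromatic carbon, a change for which the measured compounds offer no guide. With nothing to draw on, no step beyond the scatter is expected, though the uncertainty is wide; the expected step is a number 4.7 percentage points lower from compound 2 to compound 4 (within the scatter). Compound 4 is estimated to give 14%, within a range of 2% to 28%.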

Compound 4, a percentage reported as inhibition, at one concentration (the size of the read-out at that concentration, not a potency): 21.3%
Estimate against measurement, compound 4: 7.3 percentage points below, and the stated range covers the measured number.
By their numbers in this assay, from the lowest: compounds 1 and 3 (each within the scatter of the next); then compounds 2 and 4 (each within the scatter of the next).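

Carboxy in place of hydroxy on this aromatic carbon, opposite the ring nitrogen, brings a number 2.6 percentage points higher from compound 2 to compound 4 (within the scatter) in this assay and so does not move the read-out beyond the scatter. The earlier compounds shown here all carried hydroxy here, so they could not show that this place takes a group of three heavy atoms with no such step. As far as these compounds go, whether a methyl ester, a primary amide or a bare hydrogen on this carbon would read the same stays open, as does whether the change holds on the cores of compound 3 and compound 1. Nothing shown accounts for the closeness of the two numbers.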